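The source may report more compounds than this note shows. Statements on the series, on what has been measured and on what is new or still open speak of the compounds shown alone.

Of the compounds shown here, two built on the same core have been measured in a functional assay on HepG2 cells (Homo sapiens) for antiproliferative activity, read by MTT assay, with a stated time of 48 h; a lower number here means a stronger inhibitor, a higher number a weaker inhibitor. Compound 1 `CCOc1ccccc1-n1nncc1CN1C(=O)C2(C(C#N)=C(N)Oc3c2c2nc4ccccc4nc2c2ccccc32)c2ccccc21` gives only a limit there, > 50000 nM, and that figure is a limit of the assay rather than a number. Compound 2 `N#CC1=C(N)Oc2c(N)cc3nc4ccccc4nc3c2C12C(=O)N(Cc1cnnn1-c1ccccc1Cl)c1ccccc12` gives 33500 nM in this assay, the only number shown in the set, since the other entry is the limit of > 50000 nM in this assay, at which 1 of the 2 values shown sits. Compound 3 `CCOc1ccc(-n2nncc2CN2C(=O)C3(C(C#N)=C(N)Oc4c(N)cc5nc6ccccc6nc5c43)c3ccccc32)cc1` has not yet been measured. It differs from compound 2 in one place: 4-ethoxyphenyl in place of 2-chlorophenyl on an aromatic nitrogen, in words 4-ethoxyphenyl in place of 2-chlorophenyl on an aromatic nitrogen. Within the data shown here, no measured pair shows such a change, so the size of the step cannot be read from the data; no shift beyond the usual scatter is expected, in either direction. Compound 3 is therefore estimated at 35000 nM in this assay, with a range from 12000 nM to 100000 nM. The expected step, a 1.0-fold higher number from compound 2 to compound 3 (0.02 log units; within the scatter), is judged to lie within the scatter.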

Compound 3, half-maximal inhibitory concentration: > 50000 nM
Compound 3: only a limit was reported; the forecaster's own chance of this, stated with the estimate: 35%; middle value at least 1.4-fold (0.15 log units) from the limit.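

In this assay, among these compounds, putting 4-ethoxyphenyl in place of 2-chlorophenyl on the aromatic nitrogen gives an at least 1.4-fold higher number from compound 2 to compound 3 (0.17 log units; that floor lies within the scatter), the first step that can be read at this position. Compound 3 gives a limit of the assay and not a number, so this step has only a floor, its full size cannot be read, and nothing here places 4-ethoxyphenyl ahead of 2-chlorophenyl. With this result, most of the set stands at one limit: the limit of > 50000 nM in this assay, at which 2 of the 3 values shown sit.

The compounds shown leave open whether any group on this nitrogen can give a clearly lower number than compound 2, for example a phenyl ring carrying an amine or a carboxylic acid. They also leave open how a plain phenyl ring or a longer alkoxy chain would read on the same core.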